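Swapping a furan for a pyridine on a shared core

This account rests on a few compounds, and the source may have more. Where it says the series, first, only, none or still open, it means among the compounds named here.

Of the compounds shown here, three built on one shared core have been tested in an assay on isolated protein for inhibition of DNA topoisomerase 1 (Homo sapiens), with a stated time of 30 min, tested at 100 uM; on this read-out lower numbers stand for a weaker effect and higher numbers for a stronger effect at the one concentration tested. Compound 1, `Oc1ccc(-c2cc(-c3ccco3)nc(-c3ccccc3Cl)c2)cc1`, gives 3.9% in this assay. Compound 2, `Oc1ccc(-c2cc(-c3ccncc3)nc(-c3ccccc3Cl)c2)cc1`, differs from compound 1 in one place, (pyridin-4-yl in place of furan-2-yl on an aromatic carbon); in this assay compound 2 gives 9.9%, and the change made a step of a number 6 percentage points higher from compound 1 to compound 2 (within the scatter). Compound 3, `Oc1ccc(-c2cc(-c3ccc(Cl)cc3)nc(-c3ccco3)c2)cc1`, keeps the same atoms as compound 1 but joins them differently, (4-chlorophenyl in place of 2-chlorophenyl on an aromatic carbon); in this assay compound 3 gives 15.8%, and here the step was a number 11.9 percentage points higher from compound 1 to compound 3 (beyond the scatter). Compound 3 thus lies beyond compound 1, while its values and those of compound 2 sit within the usual scatter of each other.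

Compound 4, `Oc1ccc(-c2cc(-c3ccncc3)nc(-c3ccc(Cl)cc3)c2)cc1`, has not yet been measured in this assay. It differs from compound 3 by pyridin-4-yl in place of furan-2-yl on an aromatic carbon. Among the compounds with values here, this is the same kind of change as the one from compound 1 to compound 2, though not the same: in compound 1 the place is meta to a 2-chlorophenyl group, whereas in compound 3 it is meta to a 4-chlorophenyl group. The expectation for compound 4 rests on that earlier step of a number 6 percentage points higher from compound 1 to compound 2 (within the scatter), which lay within the scatter, so the step expected from compound 3 to compound 4 is estimated at a number 4.2 percentage points higher from compound 3 to compound 4 (within the scatter), a similar small shift. Within the data shown here, compound 4 is therefore estimated to give about 20% in this assay, with a likely range from 8% to 32%, since only two compounds inform this kind of change.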

Compound 4, a percentage reported as inhibition, at one concentration (the size of the read-out at that concentration, not a potency): 5.9%
For compound 4 the middle estimate is 14.1 percentage points above the measured one, and the stated range ends above it.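

In this assay the swap of furan-2-yl for pyridin-4-yl did not carry over from one core to the other: with a 4-chlorophenyl group on the core it gave a number 9.9 percentage points lower from compound 3 to compound 4 (within the scatter) and this does not match the step seen with a 2-chlorophenyl group: the same change on two cores in this assay, a number 6 percentage points higher (within the scatter) from compound 1 to compound 2 and a number 9.9 percentage points lower (within the scatter) from compound 3 to compound 4, 15.9 percentage points apart, beyond the scatter of two such steps. The change from 2-chlorophenyl to 4-chlorophenyl, read on the core that carries pyridin-4-yl, gave a number 4 percentage points lower from compound 2 to compound 4 (within the scatter) and it fails to carry over in the same way: the same change on two cores in this assay, a number 11.9 percentage points higher (beyond the scatter) from compound 1 to compound 3 and a number 4 percentage points lower (within the scatter) from compound 2 to compound 4, 15.9 percentage points apart, beyond the scatter of two such steps. So in these four compounds the effect of each change depends on what sits elsewhere on the core, but each step rests on a single pair of compounds at one concentration, which shows neither why the two changes fail to add up, nor what a further core would do, nor anything about potency.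

The compounds shown carry only furan-2-yl or pyridin-4-yl and a chlorophenyl group on the central ring, which leaves open how a plain phenyl ring, a pyridin-3-yl ring or a chain ending in an amine would behave in those places. Going by these compounds, the 4-hydroxyphenyl group stays the same throughout, so it also remains open what a methoxy group or a carboxylic acid in place of its hydroxyl would do to the read-out.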